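This account rests on a few compounds, and the source may have more. Where it says the series, first, only, none or still open, it means among the compounds named here.

Compound 3 `CCN(CC)c1ccc2cc(C(=O)NC(C)C)c(=O)oc2c1` carries an isopropyl group on an amide-type nitrogen. In a functional assay on HeLa cells (Homo sapiens) for cytotoxicity, read by MTT assay, with a stated time of 72 h (on this read-out higher numbers stand for weaker inhibition and lower numbers for stronger inhibition), compound 3 gives 73000 nM, the highest of the two numbers seen here. Compound 2 `O=C(NCCNC(=O)c1cc2ccc(OCc3ccccc3)cc2oc1=O)c1cc2ccc(OCc3ccccc3)cc2oc1=O` gives 12100 nM in this assay. Compound 1 `CCN(CC)c1ccc2cc(C(=O)NCCO)c(=O)oc2c1`, which carries 2-hydroxyethyl on that nitrogen, reaches only a limit of this assay, > 100000 nM, and that value is a limit rather than a number. Within the data shown here, the single step between measured compounds differing in one place is an at least 1.3-fold lower number from compound 1 to compound 3 (0.13 log units; that floor lies within the scatter), whose floor is set by the limit of > 100000 nM in this assay, at which 1 of the 3 values shown sits. Compound 4 `CCN(CC)c1ccc2cc(C(=O)NO)c(=O)oc2c1` differs from compound 3 in one place: hydroxy in place of isopropyl on an amide-type nitrogen. Among the measured compounds shown here, the only measured step touching this nitrogen, the swap from 2-hydroxyethyl to isopropyl, gave nothing separable from the scatter. For the measured compounds named here, the entering hydroxy group has no measured counterpart here, so the expectation rests on that small step: for compound 4 no step beyond the scatter is expected, a 1.0-fold lower number from compound 3 to compound 4 (0.02 log units; within the scatter). Compound 4 is therefore estimated at 70000 nM, with a range from 20000 nM to 200000 nM.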

Compound 4, half-maximal inhibitory concentration: 35900 nM
Beside the measured number, compound 4's estimate is 1.9-fold (0.29 log units) above it; the range from low to high includes it.
By their numbers in this assay, from the lowest: compound 2; then compound 4; then compound 3. At a limit, above all of these: compound 1.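

Among these compounds, on this amide-type nitrogen, hydroxy in place of isopropyl gives a 2.0-fold lower number from compound 3 to compound 4 (0.31 log units; beyond the scatter) in this assay, the first step here that clears the scatter. Hydroxy in place of 2-hydroxyethyl gives an at least 2.7-fold lower number from compound 1 to compound 4 (0.44 log units; beyond the scatter) and so also clears it, whereas the earlier swap between 2-hydroxyethyl and isopropyl did not. That second step is only a floor, as compound 1 stands at a limit and not at a number: the limit of > 100000 nM in this assay, at which 1 of the 4 values shown sits.

Going by these compounds, whether the lower number follows from the hydroxy group itself or from the loss of the carbon atoms remains open, and a methyl or a methoxy group on this nitrogen could help separate the two. Also open, on these data alone, is whether the step would hold in any other cell line.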